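Swapping a Six-Membered Ring for Five on a Chromone

The source may report more compounds than this note shows. Statements on the series, on what has been measured and on what is new or still open speak of the compounds shown alone.

Three compounds sharing a chromone core carry a dithiocarbamate arm. In a functional assay on MCF7 cells (Homo sapiens) for antiproliferative activity, read by MTT assay, with a stated time of 72 h (a higher number here means a weaker inhibitor, a lower number a stronger inhibitor), compound 1 `Cc1ccc2c(=O)c(CSC(=S)N3CCCCC3)coc2c1` gives 800 nM. Compound 2 `CCOC(=O)c1cc(=O)c2cc(CSC(=S)N(C)c3ccccc3)ccc2o1` gives > 25000 nM in this assay, which is a limit rather than a number. Compound 3 `O=c1cc(CSC(=S)N2CCCCC2)oc2cc(Cl)ccc12` likewise gives > 25000 nM in this assay, again a limit. Compound 3 therefore stands at the weak edge of what is shown, sharing the limit of > 25000 nM in this assay, at which 2 of the 3 values shown sit, with compound 2, while compound 1 is the only one with a measured number.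

Compound 4 `O=c1cc(CSC(=S)N2CCCC2)oc2cc(Cl)ccc12` differs from compound 3 by pyrrolidin-1-yl in place of piperidin-1-yl on a thiocarbonyl carbon, a pyrrolidin-1-yl in place of piperidin-1-yl on a thiocarbonyl carbon. Within the data shown here, no measured pair in this set shows such a swap, so there is no measured step to lean on. Because compound 3 sits at > 25000 nM, a limit, the expected step of a number no higher from compound 3 to compound 4 (the limit leaves the size open) is none beyond the scatter, with compound 4 most likely also reported as a limit. Compound 4 is estimated at 25000 nM, within 8000 nM to 60000 nM.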

Compound 4, half-maximal inhibitory concentration: > 25000 nM
Compound 4 was reported as a limit; the forecaster's own chance of this, stated with the estimate: 70%; the middle value sits exactly at the limit.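

Compound 3 and compound 4 both stop at the same limit, so pyrrolidin-1-yl in place of piperidin-1-yl gives no readable step between them: the limit of > 25000 nM in this assay, at which 3 of the 4 values shown sit. The compounds shown leave open what this swap does on a compound with a measured number, such as compound 1 at 800 nM.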